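A few compounds are considered here, and "the series" means these few. Any claim that something is new, unique, unknown or untested is made for them only; others in the source may bear on it.

In a functional assay on MIA PaCa-2 cells (Homo sapiens) for inhibition, read by MTT assay, with a stated time of 48 h, tested at 10 uM (on this read-out higher numbers stand for more inhibition of growth at the one concentration tested and lower numbers for less inhibition of growth), compound 1 `CCN(CC)Cc1c(O)c([C@H]2CCN(C)C[C@H]2O)c2oc(C)cc(=O)c2c1O` gives 27% and compound 2 `Cc1cc(=O)c2c(O)c(CN3CCN(C(=O)OC(C)(C)C)CC3)c(O)c([C@H]3CCN(C)C[C@H]3O)c2o1` gives 6% as its reading. Compound 3 `Cc1cc(=O)c2c(O)c(CN(C)CC(=O)O)c(O)c([C@H]3CCN(C)C[C@H]3O)c2o1` gives 16% which lies within the scatter of compound 2 and beyond the scatter of compound 1. Compound 4 `CCOC(=O)N1CCN(Cc2c(O)c([C@H]3CCN(C)C[C@H]3O)c3oc(C)cc(=O)c3c2O)CC1` is still unmeasured. The change 4-(ethoxycarbonyl)piperazin-1-yl in place of (carboxymethyl)(methyl)amino on a saturated chain carbon bound to an aromatic carbon leads from compound 3 to compound 4 on a saturated chain carbon bound to an aromatic carbon. Among the measured compounds shown here, only one measured step swaps the group at this place: a number 11 percentage points lower from compound 1 to compound 3 (beyond the scatter) is a modest one. For the measured compounds named here, with compound 2 (6%) as the only other guide, a small downward move is expected in this assay here. The expected change is a number 5 percentage points lower from compound 3 to compound 4 (within the scatter) and it stays within the scatter. Compound 4 is estimated at 11% with a likely range from 2% to 24% on this scale.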

Compound 4, percent growth inhibition at one concentration: 4%
For compound 4 the middle estimate is 7 percentage points above the measured one; measured number inside the range.
By their numbers in this assay, from the lowest: compounds 4, 2 and 3 (each within the scatter of the next, the first and the last beyond it); then compound 1.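

In this assay a group carrying a substituted piperazine ring, on a saturated chain carbon bound to an aromatic carbon, reads low: 4-(ethoxycarbonyl)piperazin-1-yl gives a number 12 percentage points lower from compound 3 to compound 4 (beyond the scatter) and a number 23 percentage points lower from compound 1 to compound 4 (beyond the scatter). Ethyl in place of tert-butyl on an oxygen next to a carbonyl group gives a number 2 percentage points lower from compound 2 to compound 4 (within the scatter), so this swap cannot be told apart from scatter. No measurement here explains these differences. As far as these compounds go, whether a piperazine with a free amine in place of the ethoxycarbonyl, or a morpholine ring, would read closer to diethylamino stays open.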